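Chloro to hydroxy on the aryl ring of compound 3

The compounds below may be only part of what the source reports. "The series", "measured", "known", "first", "only" and "open" are said of these compounds alone.

Within the data shown here, in a functional assay on the whole organism (strain albino) for inhibition, with Rattus norvegicus as the target, read by paw edema, with stated times of 1 h and 3 h, at a dose of 100 mg/kg by the oral route (on this read-out lower numbers stand for a weaker effect and higher numbers for a stronger effect at the one dose given), the three measured members sit close together. Compound 1 `N#Cc1c(Cl)nc(SCC(=O)Nn2c(COc3ccc(Cl)cc3Cl)nc3ccccc3c2=O)nc1-c1ccc(Cl)cc1` gives 68.4%. Compound 2 `N#Cc1c(Cl)nc(SCC(=O)Nn2c(COc3ccc(Cl)cc3Cl)nc3ccccc3c2=O)nc1-c1ccc(O)cc1` gives 73.7%, and the step of a number 5.3 percentage points higher from compound 1 to compound 2 (within the scatter) stays within the scatter. Compound 3 `N#Cc1c(Nc2ccc(Cl)cc2)nc(SCC(=O)Nn2c(COc3ccc(Cl)cc3Cl)nc3ccccc3c2=O)nc1-c1ccc(Cl)cc1` gives 64.9%; the step of a number 3.5 percentage points lower from compound 1 to compound 3 (within the scatter) is likewise within the scatter. Compound 3 thus stands at the lower end of the three numbers, but its distance to compound 1 and to compound 2 is within the scatter in both cases, so no ordering among them can be claimed.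

Compound 4 `N#Cc1c(Nc2ccc(Cl)cc2)nc(SCC(=O)Nn2c(COc3ccc(Cl)cc3Cl)nc3ccccc3c2=O)nc1-c1ccc(O)cc1` differs from compound 3 by hydroxy in place of chloro on an aromatic carbon. Among the measured compounds shown here, the only measured step that bears on this change is a number 5.3 percentage points higher from compound 1 to compound 2 (within the scatter), the same exchange made on the core of compound 1, which stayed within the scatter. The expectation for compound 4 in this assay is therefore a step of similar size, a number 5.1 percentage points higher from compound 3 to compound 4 (within the scatter), not beyond the scatter. Compound 4 is estimated at 70%, with a range from 58% to 82%.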

Compound 4, a percentage reported as inhibition, in the whole organism at one dose (the size of the read-out at that dose, not a potency): 79%
Compound 4: middle estimate off by 9 percentage points, on the low side; low and high end bracket the measured number.
By their numbers in this assay, from the lowest: compounds 3, 1, 2 and 4 (each within the scatter of the next, the first and the last beyond it).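

In this assay, hydroxy in place of chloro on an aromatic carbon, para to a large group, now gives a step that stands clear of the scatter, a number 14.1 percentage points higher from compound 3 to compound 4 (beyond the scatter). The larger step does not establish that the change depends on the core, as the two readings of it do not differ beyond the scatter: the same change on two cores in this assay, a number 5.3 percentage points higher (within the scatter) from compound 1 to compound 2 and a number 14.1 percentage points higher (beyond the scatter) from compound 3 to compound 4, 8.8 percentage points apart, within the scatter of two such steps. The (4-chlorophenyl)amino exchange, now read with hydroxy in place, gives a number 5.3 percentage points higher from compound 2 to compound 4 (within the scatter), and its two readings also agree within the scatter: the same change on two cores in this assay, a number 3.5 percentage points lower (within the scatter) from compound 1 to compound 3 and a number 5.3 percentage points higher (within the scatter) from compound 2 to compound 4, 8.8 percentage points apart, within the scatter of two such steps.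

On these data alone, whether an amine or a methoxy group at the same place would match hydroxy remains open. As far as these compounds go, with a single dose and a read-out of effect size, the potency of compound 4 also remains open.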